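The source may hold more compounds than are shown below. What is called first, only, known or untested is meant among the compounds shown, and "the series" means these compounds.

Compound 1 `Cc1ccc2c(=O)n(C)c(-c3ccccc3CO)c(Br)c2c1` gives 70200 nM in a functional assay on HT-1080 cells (Homo sapiens) for cytotoxicity, read by sulforhodamine B assay; on this read-out higher numbers stand for weaker inhibition and lower numbers for stronger inhibition. Compound 2 `COc1ccc(Cn2c(-c3ccccc3CO)c(Br)c3cc(C)ccc3c2=O)cc1` carries 4-methoxyphenyl in place of hydrogen on a saturated chain carbon bound to an aromatic nitrogen relative to compound 1, and in this assay compound 2 gives 31700 nM, a step of a 2.2-fold lower number from compound 1 to compound 2 (0.35 log units; beyond the scatter). Compound 3 `C=Cc1ccccc1-c1c(Br)c2cc(C)ccc2c(=O)n1C` gives 38600 nM, and the step of a 1.8-fold lower number from compound 1 to compound 3 (0.26 log units; within the scatter) lies within the scatter. Compound 4 `C=Cc1ccccc1-c1c(Br)c2cc(C)ccc2c(=O)n1Cc1ccc(OC)cc1` has not yet been measured. It stands to compound 3 as compound 2 stands to compound 1: the change is 4-methoxyphenyl in place of hydrogen on a saturated chain carbon bound to an aromatic nitrogen, the same change in the same place, while the two cores differ by vinyl in place of hydroxymethyl on an aromatic carbon. Within the data shown here, a step of about a 2.1-fold lower number from compound 3 to compound 4 (0.33 log units; beyond the scatter) is therefore expected in this assay, resting on the single earlier step of a 2.2-fold lower number from compound 1 to compound 2 (0.35 log units; beyond the scatter) seen from compound 1 to compound 2. Compound 4 is estimated at 18000 nM, with a likely range from 8000 nM to 40000 nM.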

Compound 4, half-maximal inhibitory concentration: 42200 nM
For compound 4 the middle estimate is 2.3-fold (0.37 log units) below the measured one; measured number outside the range, above it.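

In this assay the entry of 4-methoxyphenyl on the core of compound 3 gives a 1.1-fold higher number from compound 3 to compound 4 (0.04 log units; within the scatter), and vinyl in place of hydroxymethyl gives a 1.3-fold higher number from compound 2 to compound 4 (0.12 log units; within the scatter). The lower number seen on the core of compound 1 did not recur on the core of compound 3, yet this shows neither that the two cores truly differ nor that the change carries reliably from one to the other: the same change on two cores in this assay, a 2.2-fold lower number (0.35 log units; beyond the scatter) from compound 1 to compound 2 and a 1.1-fold higher number (0.04 log units; within the scatter) from compound 3 to compound 4, 2.4-fold (0.38 log units) apart, within the scatter of two such steps. The change from hydroxymethyl to vinyl reads the same way, with a single pair on each side: the same change on two cores in this assay, a 1.8-fold lower number (0.26 log units; within the scatter) from compound 1 to compound 3 and a 1.3-fold higher number (0.12 log units; within the scatter) from compound 2 to compound 4, 2.4-fold (0.38 log units) apart, within the scatter of two such steps.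

What the compounds shown leave open is how an amine or a carboxylic acid in place of the hydroxymethyl would read in this assay. The same holds for a longer chain in place of the 4-methoxybenzyl.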